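This account rests on a few compounds, and the source may have more. Where it says the series, first, only, none or still open, it means among the compounds named here.

In a functional assay on PC-3 cells (Homo sapiens) for inhibition, read by MTT assay, with a stated time of 48 h (a lower number here means a stronger inhibitor, a higher number a weaker inhibitor), three compounds with a shared core have been measured so far. Compound 1 `COc1ccc(-n2c(SCC(=O)c3ccccc3)nnc2-c2cc(OC)c(OC)c(OC)c2)cc1` gives > 60000 nM, which is a limit of the assay and not a number. Compound 2 `COc1cc(-c2nnc(SC)n2-c2ccc(N(C)C)cc2)cc(OC)c1OC` gives > 60000 nM, again a limit. Going by the values given here, compound 3 `COc1cc(-c2nnc(SCC(=O)c3ccccc3)n2-c2ccc(N(C)C)cc2)cc(OC)c1OC` gives 38600 nM, the only true number of the three.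

Two measured steps lead to it: an at least 1.5-fold lower number from compound 1 to compound 3 (0.19 log units; that floor lies within the scatter), with dimethylamino in place of methoxy on an aromatic carbon, and an at least 1.5-fold lower number from compound 2 to compound 3 (0.19 log units; that floor lies within the scatter), with benzoyl in place of hydrogen on a saturated chain carbon bound to a sulfur. Both are floors rather than full sizes.

Compound 4 `COc1cc(-c2nnc(SCC(=O)Nc3ccc(Cl)cc3)n2-c2ccc(N(C)C)cc2)cc(OC)c1OC` differs from compound 3 in one place: (4-chlorophenyl)amino in place of phenyl on a carbonyl carbon. In short, (4-chlorophenyl)amino stands in place of phenyl on a carbonyl carbon. Among the compounds with values here, the second step bears more closely, as it concerns the same chain, but no measured step makes this exchange. In this assay, therefore, no change beyond the scatter is expected, with only a slight lean towards a lower number. The expected step is a 1.5-fold lower number from compound 3 to compound 4 (0.19 log units; within the scatter). The estimate for compound 4 is 25000 nM, with an expected range of 6000 nM to 60000 nM.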

Compound 4, half-maximal inhibitory concentration: > 60000 nM
Compound 4 gave a limit, no number; the forecaster's own chance of this, stated with the estimate: 25%; middle value at least 2.4-fold (0.38 log units) away from the limit.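

In this assay, putting (4-chlorophenyl)amino in place of phenyl on the carbonyl carbon gives an at least 1.5-fold higher number from compound 3 to compound 4 (0.19 log units; that floor lies within the scatter), so this exchange brings no gain at this position, although the floor alone does not establish a loss beyond the scatter. From the compounds shown here alone, compound 4 gives > 60000 nM, which is a limit of the assay and not a number, so the full size of the step remains unknown, and the step that joins the limits of compound 2 and compound 4 cannot be read. The benzoyl group of compound 3 is thus the only chain end shown here that yields a true number, and the series offers little room for comparison: the limit of > 60000 nM in this assay, at which 3 of the 4 values shown sit.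

The compounds shown leave open whether the chlorine or the amide hydrogen matters more to this outcome, a question that a plain phenylamino group on the same carbonyl carbon would address. They also leave open whether a substituted benzoyl group, such as 4-chlorobenzoyl, would keep a readable number or move it beyond the scatter from that of compound 3.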